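Thiadiazole to Oxadiazole: Compound 4 Expected to Stay Inactive

This account rests on a few compounds, and the source may have more. Where it says the series, first, only, none or still open, it means among the compounds named here.

Compound 3 `Cc1ccc2oc(CSc3nnc(C)s3)cc(=O)c2c1` has been tested in a functional assay on HEp-2 cells (Homo sapiens) for cytotoxicity, read by MTT assay, with a stated time of 72 h; on this read-out lower numbers stand for stronger inhibition and higher numbers for weaker inhibition. In this assay compound 3 gives > 25000 nM, which is a limit of the assay and not a number. Compound 4 `Cc1ccc2oc(CSc3nnc(C)o3)cc(=O)c2c1` differs from compound 3 in one place: 5-methyl-1,3,4-oxadiazol-2-yl in place of 5-methyl-1,3,4-thiadiazol-2-yl on a sulfur. Two measured compounds already carry this oxadiazolyl group. Compound 1 `Cc1nnc(SCc2cc(=O)c3cc(Cl)ccc3o2)o1` gives > 25000 nM in this assay, a limit rather than a number. Compound 2 `Cc1nnc(SCc2cc(=O)c3ccccc3o2)o1` gives > 25000 nM in this assay, again a limit. Going by the values given here, the step that the two limits leave unreadable from compound 1 to compound 2 is unreadable; both of its ends are limits, so no measured step speaks directly to the exchange of thiadiazolyl for oxadiazolyl. All three values rest at the same point, (the limit of > 25000 nM in this assay, at which 3 of the 3 values shown sit). The expected step is a step that the limit leaves unreadable from compound 3 to compound 4, that is, no change beyond the scatter. The estimated value for compound 4 in this assay is 50000 nM, with a range from 25000 nM to 200000 nM, and the result is expected to be reported once more only as a limit.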

Compound 4, half-maximal inhibitory concentration: > 25000 nM
Compound 4: no number, only a limit; the forecaster's own chance of this, stated with the estimate: 90%; the middle value lies beyond the limit too.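

Compound 4, like compounds 1, 2 and 3, is reported in this assay only as a limit and not as a number, so no step among these compounds can be read: the limit of > 25000 nM in this assay, at which 4 of the 4 values shown sit.

The compounds shown leave open whether 5-methyl-1,3,4-oxadiazol-2-yl and 5-methyl-1,3,4-thiadiazol-2-yl differ at all in their effect on these cells.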